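The compounds below may be only part of what the source reports. "The series", "measured", "known", "first", "only" and "open" are said of these compounds alone.

Compound 1 `CCCCCCCCc1ccc(OCC(=O)Cn2nnc(SC)n2)cc1`: 31 nM
Compound 2 `CCCCCCCCc1ccc(OCC(=O)Cn2nnc(-c3ccc(Cl)cc3)n2)cc1`: 35 nM
Compound 3 `CCCCCCCCc1ccc(OCC(=O)Cn2nnc(-c3cccc(Cl)c3)n2)cc1`: 24 nM

In an assay on microsomes from brain for inhibition of Fatty-acid amide hydrolase 1 (Rattus norvegicus), read by fluorescence and HPLC, with a stated time of 60 min (a higher number here means a weaker inhibitor, a lower number a stronger inhibitor), compound 3 holds the lowest of the three numbers, yet its distances to both others stay within the scatter: a 1.3-fold lower number from compound 1 to compound 3 (0.11 log units; within the scatter) and a 1.5-fold lower number from compound 2 to compound 3 (0.16 log units; within the scatter). Compound 4 `CCCCCCCCc1ccc(OCC(=O)Cn2nnc(-c3ccc(C(=O)OC)cc3)n2)cc1` carries 4-(methoxycarbonyl)phenyl in place of 3-chlorophenyl on an aromatic carbon. The measured steps that bear on this change are the earlier exchanges of the group on the same aromatic carbon, a 1.1-fold higher number from compound 1 to compound 2 (0.05 log units; within the scatter) and a 1.5-fold lower number from compound 2 to compound 3 (0.16 log units; within the scatter), none of them beyond the scatter. A step of comparable size is therefore expected in this assay, a 1.5-fold higher number from compound 3 to compound 4 (0.16 log units; within the scatter), with no direction beyond the scatter. Compound 4 is accordingly estimated at 35 nM in this assay, within a range from 12 nM to 100 nM.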

Compound 4, half-maximal inhibitory concentration: 29 nM
For compound 4 the middle estimate is 1.2-fold (0.08 log units) above the measured one; the measured number falls inside the stated range.
By their numbers in this assay, from the lowest: compounds 3, 4, 1 and 2 (each within the scatter of the next).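

In this assay, the larger 4-(methoxycarbonyl)phenyl, which brings hydrogen-bond acceptors that 3-chlorophenyl lacks, shows no difference beyond the scatter, with a 1.2-fold higher number from compound 3 to compound 4 (0.08 log units; within the scatter). The same holds for methoxycarbonyl in place of chloro, with a 1.2-fold lower number from compound 2 to compound 4 (0.08 log units; within the scatter), and for the exchange with methylsulfanyl, with a 1.1-fold lower number from compound 1 to compound 4 (0.03 log units; within the scatter), so all four groups on this aromatic carbon give matching numbers. Nothing available explains this lack of separation. Going by these compounds, whether an amine or a carboxylic acid on the phenyl ring would separate from these compounds remains open.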